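From formyl to 2-cyanoethenyl: working notes on the series

The source may hold more compounds than are shown below. What is called first, only, known or untested is meant among the compounds shown, and "the series" means these compounds.

Measured so far in a functional assay on Jurkat cells (Homo sapiens) for cytotoxicity, with a stated time of 72 h (on this read-out lower numbers stand for an effect already at smaller amounts and higher numbers for an effect only at larger amounts of compound), each entry a limit of the assay and not a number:
Compound 1 (`C=C[C@@](C)(/C=C/c1ccc(O)cc1)CCC=O`) gives > 49000 nM as a limit
Compound 2 (`C=C[C@@](C)(/C=C/c1ccc(O)c(CO)c1)CCC=C(C)C`) gives > 49000 nM as a limit
Compound 3 (`C=C[C@@](C)(/C=C/c1ccc(O)c(C=O)c1)CCC=C(C)C`) gives > 49000 nM as a limit

Compound 3 has no number in this assay and stands only at a limit, as do compound 1 and compound 2. The evidence so far comes down to the limit of > 49000 nM in this assay, at which 3 of the 3 values shown sit, and nothing more.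

The next change leads to compound 4 (`C=C[C@@](C)(/C=C/c1ccc(O)c(/C=C/C#N)c1)CCC=C(C)C`) and is 2-cyanoethenyl in place of formyl on an aromatic carbon, with 2-cyanoethenyl in place of formyl on an aromatic carbon, ortho to a hydroxy group.

Among the measured compounds shown here, the only measured step involving the formyl group is a step that the two limits leave unreadable from compound 2 to compound 3, and it has no readable size. For the measured compounds named here, no measured step therefore gives a size to carry over. The expectation rests on that step and on the shared limit, so compound 4 is expected to stay close to the limit or at it. The estimated change, an at least 1.2-fold lower number from compound 3 to compound 4 (0.08 log units; that floor lies within the scatter), would lean towards lower numbers if it shows at all. For compound 4 the estimate is 40000 nM, in an expected range of 12000 nM to 70000 nM, and a report of a limit alone remains the likelier outcome.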

Compound 4, half-maximal effective concentration: > 49000 nM
Compound 4 was reported as a limit; the forecaster's own chance of this, stated with the estimate: 65%; at least 1.2-fold (0.08 log units) between middle value and limit.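

In this assay compound 4 gives > 49000 nM as a limit of the assay and not a number. With compound 2, compound 3 and compound 4 all standing at limits, no new step can be read among them. The compounds shown leave open whether hydroxymethyl, formyl or 2-cyanoethenyl on the aromatic carbon makes any difference in this assay at all.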